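Swapping Hydroxy for Carboxy on the Shared Core

The source may report more compounds than this note shows. Statements on the series, on what has been measured and on what is new or still open speak of the compounds shown alone.

Of the compounds shown here, three built on one core have been measured in a functional assay on A-375 cells (Homo sapiens) for antiproliferative activity, read by MTT assay, with a stated time of 24 h, tested at 3.7 ug/mL; a lower number here means a weaker effect, a higher number a stronger effect of the compound at the concentration tested. Compound 1 `Cc1c(C(=O)Nc2c(F)cc(-c3cccc(F)c3)cc2F)nc2ccc(F)cc2c1O` gives 7.85%. Compound 2 `Cc1c(C(=O)Nc2c(F)cc(-c3cccc(F)c3)cc2F)nc2ccc(OC(F)(F)F)cc2c1O` gives 2.06%, and compound 3 `Cc1c(C(=O)Nc2c(F)cc(-c3cccc(F)c3)cc2F)nc2ccc(C(F)(F)F)cc2c1O` gives 34.3%. Compound 1 thus stands second highest of the three: the step of a number 5.8 percentage points lower from compound 1 to compound 2 (within the scatter) lies within the scatter, whereas the step of a number 26.5 percentage points higher from compound 1 to compound 3 (beyond the scatter) lies beyond it, as does the step of a number 32.2 percentage points higher from compound 2 to compound 3 (beyond the scatter).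

Compound 4 `Cc1c(C(=O)Nc2c(F)cc(-c3cccc(F)c3)cc2F)nc2ccc(F)cc2c1C(=O)O` differs from compound 1 at another spot: carboxy in place of hydroxy on an aromatic carbon. Among the measured compounds shown here, each of the three measured steps exchanges a fluoro, trifluoromethoxy or trifluoromethyl group elsewhere on the core and leaves the hydroxy untouched, so no measured step bears on this change. With nothing to guide a direction, the expected step is a number 0.2 percentage points higher from compound 1 to compound 4 (within the scatter), small and uncertain. Compound 4 is estimated to give 8% in this assay, within a range from 0% to 30%.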

Compound 4, a percentage reported as inhibition, at one concentration (the size of the read-out at that concentration, not a potency): 24.5%
For compound 4 the middle estimate is 16.5 percentage points below the measured one; low and high end bracket the measured number.
By their numbers in this assay, from the lowest: compounds 2 and 1 (each within the scatter of the next); then compounds 4 and 3 (each within the scatter of the next).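

Among the compounds shown here, this is the first change at the position opposite the ring nitrogen, and in this assay carboxy in place of hydroxy gives a number 16.7 percentage points higher from compound 1 to compound 4 (beyond the scatter) on the core of compound 1. The earlier steps shown here all exchanged a group elsewhere on the core, so they showed only that the read-out responds to changes at that other spot; this step shows that it also responds to a change at this position. Nothing in the available data gives a reason for this rise.

Carboxy is seen here only alongside fluoro, so it remains open whether the same swap would raise the read-out alongside trifluoromethyl or trifluoromethoxy. Going by these compounds, it is also open how other groups at this position, such as an amine, a methyl ester or a primary amide, would compare with hydroxy and carboxy.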